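Glucagon receptor antagonists: shortening the chain on the benzylic carbon

The source may hold more compounds than are shown below. What is called first, only, known or untested is meant among the compounds shown, and "the series" means these compounds.

Three compounds of the series have numbers in a functional assay on CHO cells for antagonist activity at Glucagon receptor (Homo sapiens), read by cAMP accumulation, with stated times of 30 min and 45 min; a lower number here means a stronger inhibitor, a higher number a weaker inhibitor. Compound 1 `CC(C)(C)CC[C@H](c1ccc(C(=O)NCc2nn[nH]n2)cc1)N1C(=O)C(c2cncc(Cl)c2)=N[C@]12CC[C@@H](C(C)(C)C)CC2` gives 480 nM, compound 3 `C[C@H](c1ccc(C(=O)NCCC(=O)O)cc1)N1C(=O)C(c2ccc(F)cc2)=N[C@]12CC[C@@H](C(C)(C)C)CC2` gives 430 nM, and compound 2 `CC1(CC[C@H](c2ccc(C(=O)NCc3nn[nH]n3)cc2)N2C(=O)C(c3cc(Cl)cc(Cl)c3)=N[C@]23CC[C@@H](C(C)(C)C)CC3)CC1` gives 100 nM, the lowest of the three; the gaps from compound 2 to compound 3 and to compound 1 both lie beyond the scatter, so compound 2 is the strongest inhibitor measured in this assay. Compound 4 `CC(C)[C@H](c1ccc(C(=O)NCc2nn[nH]n2)cc1)N1C(=O)C(c2cc(Cl)cc(Cl)c2)=N[C@]12CC[C@@H](C(C)(C)C)CC2` has not been measured. It differs from compound 2 in one place: isopropyl in place of 2-(1-methylcyclopropyl)ethyl on a saturated chain carbon bound to an amide-type nitrogen in a ring and an aromatic carbon. Going by the values given here, no step between measured compounds matches this change. A modest rise in the number, probably beyond the scatter, is expected for the step of a 3.5-fold higher number from compound 2 to compound 4 (0.54 log units; beyond the scatter). For compound 4 the estimate in this assay is 350 nM, ranging from 120 nM to 1000 nM.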

Compound 4, half-maximal inhibitory concentration: 2200 nM
Beside the measured number, compound 4's estimate is 6.3-fold (0.80 log units) below it; measured number above the stated range.
By their numbers in this assay, from the lowest: compound 2; then compounds 3 and 1 (each within the scatter of the next); then compound 4.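

In this assay, going by these compounds alone, isopropyl in place of 2-(1-methylcyclopropyl)ethyl on this saturated chain carbon gives a 22-fold higher number from compound 2 to compound 4 (1.34 log units; beyond the scatter), a large step and the first comparison that changes this position alone. The position is therefore sensitive to the group it carries, at least for this pair on the dichlorophenyl-bearing core of compound 2. No data on hand bear on the cause of the step. The two groups differ in both size and the three-membered ring, so the pair cannot separate these features. An n-pentyl chain at this carbon on the same core would address that question.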